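Working notes: the step from compound 2 to compound 3

The source may report more compounds than this note shows. Statements on the series, on what has been measured and on what is new or still open speak of the compounds shown alone.

Of the compounds shown here, two have numbers so far in an ADME assay on microsomes from liver (Homo sapiens) for metabolic stability, read by LC-MS, with a stated time of 30 min, tested at 1 uM (on this read-out higher numbers stand for a more stable compound and lower numbers for a less stable compound), and they sit well apart. Compound 1 `O=C(NCc1ccc(S(=O)(=O)c2cccc(C(F)(F)F)c2)cc1)c1cc2cnccc2[nH]1` stands at 81% and compound 2 `O=C(NCc1ccc(S(=O)(=O)N2CCCCC2)cc1)c1cc2ccncc2[nH]1` stands at 50% as the lower of the two numbers, a gap beyond the usual scatter. These two differ in more than one place, so the gap cannot be tied to any single change. Compound 3 `O=C(NCc1ccc(S(=O)(=O)N2CCCCC2)cc1)c1cc2ccncc2o1` differs from compound 2 by a group of 9 heavy atoms (7 carbon, 1 nitrogen, 1 oxygen; one five-membered aromatic ring with 1 hetero atom, one six-membered aromatic ring with 1 hetero atom) in place of a group of 9 heavy atoms (7 carbon, 2 nitrogen; one five-membered aromatic ring with 1 hetero atom, one six-membered aromatic ring with 1 hetero atom), on a carbonyl carbon and by nothing else. Within the data shown here, no measured pair shows this change, so its size and direction have no direct guide in this assay for now. The expected step of a number 2 percentage points higher from compound 2 to compound 3 (within the scatter) is estimated to stay within the scatter, with no firm direction. The anchor for that expectation is compound 2 at 50% alone. Compound 3 is expected at 52% with an estimated range from 30% to 72% for repeat measurements.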

Compound 3, percent of the compound remaining: 56%
Compound 3: middle estimate off by 4 percentage points, on the low side; the measured number falls inside the stated range.
By their numbers in this assay, from the lowest: compounds 2 and 3 (each within the scatter of the next); then compound 1.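

In this assay, among these compounds, the exchange on the carbonyl carbon gives a number 6 percentage points higher from compound 2 to compound 3 (within the scatter) and is the first step that can be read at a single place. The entering group has 0 hydrogen-bond donors and 2 hydrogen-bond acceptors, the leaving group 1 of each, and this exchange does not separate compound 2 from compound 3 on this read-out. Nothing measured on these compounds bears on this result.

From the compounds shown here alone, how a plain phenyl ring or a simple amine on the same carbonyl carbon would read in this assay remains open. Also open, going by these compounds, is whether the same exchange in the setting of compound 1 would give a step of similar size.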